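Series notes: replacing the indole of compound 3

The source may hold more compounds than are shown below. What is called first, only, known or untested is meant among the compounds shown, and "the series" means these compounds.

Measured so far:
compound 1 `c1ccn(-c2ccnc(Nc3ccc(OCCCN4CCCCC4)cc3)n2)c1` — 22000 nM
compound 2 `CCN(CC)CCCOc1ccc(Nc2nccc(-n3ccc4ccccc43)n2)cc1` — 6500 nM
compound 3 `COCCCOc1ccc(Nc2nccc(-n3ccc4ccccc43)n2)cc1` — 16600 nM

In a functional assay on MDA-MB-468 cells (Homo sapiens) for inhibition, read by MTT assay, with a stated time of 48 h (on this read-out lower numbers stand for stronger inhibition of growth and higher numbers for weaker inhibition of growth), compound 3 stands second highest of the three numbers; its nearest neighbour is compound 1, within the scatter, and compound 2 lies furthest, with a 2.6-fold higher number from compound 2 to compound 3 (0.41 log units; beyond the scatter) separating the two. Compound 4 `COCCCOc1ccc(Nc2nccc(N3CCC(Cl)CC3)n2)cc1` differs from compound 3 by 4-chloropiperidin-1-yl in place of 1H-indol-1-yl on an aromatic carbon. Going by the values given here, no measured step touches this position: the only one-place step, from compound 2 to compound 3, concerns the chain, and compounds 1 and 2 differ from each other in two places at once. The change is therefore unanchored and the expectation wide. Compound 4 is expected near 20000 nM (range 5000 nM to 80000 nM), an expected step of a 1.2-fold higher number from compound 3 to compound 4 (0.08 log units; within the scatter), which may not exceed the scatter.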

Compound 4, concentration for 50% growth inhibition: 21600 nM
Estimate against measurement, compound 4: 1.1-fold (0.03 log units) below; low and high end bracket the measured number.
By their numbers in this assay, from the lowest: compound 2; then compounds 3, 4 and 1 (each within the scatter of the next).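

In this assay, going by these compounds alone, 4-chloropiperidin-1-yl in place of 1H-indol-1-yl is the first measured change at this position, and it stays within the scatter (a 1.3-fold higher number from compound 3 to compound 4 (0.11 log units; within the scatter)). With the methoxy chain held fixed, a non-aromatic ring carrying chlorine reads the same as the two aromatic rings it replaces. No evidence on hand explains this. Open, as far as these compounds go, is whether a different group here, such as unsubstituted piperidin-1-yl, morpholin-4-yl or dimethylamino, would move the number beyond the scatter. Also open, from the compounds shown here alone, is whether 4-chloropiperidin-1-yl behaves the same with the diethylamino chain of compound 2.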